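A few compounds are considered here, and "the series" means these few. Any claim that something is new, unique, unknown or untested is made for them only; others in the source may bear on it.

Measured so far:
compound 1, `O=C(O)c1ccc2c(CN3CCC[C@H](O[C@H](CO)c4cc(Cl)cc(Cl)c4)[C@@H]3c3ccccc3)c[nH]c2c1`, 22000 nM;
compound 2, `Clc1cc(Cl)cc(CO[C@H]2CCCN(Cc3ncco3)[C@H]2c2ccccc2)c1`, > 200000 nM.

Of the compounds shown here, two have been measured in an assay on isolated protein for activation of cGMP-dependent protein kinase 1 (Homo sapiens), read by ADP-Glo, with stated times of 120 min and 40 min; on this read-out higher numbers stand for an effect only at larger amounts of compound and lower numbers for an effect already at smaller amounts. Compound 1 `O=C(O)c1ccc2c(CN3CCC[C@H](O[C@H](CO)c4cc(Cl)cc(Cl)c4)[C@@H]3c3ccccc3)c[nH]c2c1` gives 22000 nM. Compound 2 `Clc1cc(Cl)cc(CO[C@H]2CCCN(Cc3ncco3)[C@H]2c2ccccc2)c1` reaches only the limit of this assay, > 200000 nM, so no number is known for it; it sits at the limit of > 200000 nM in this assay, at which 1 of the 2 values shown sits. Going by the values given here, of the two measured values, that of compound 1 is therefore the only real number, and compound 2 stands no better than the edge of what this assay can report.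

Compound 3 `O=C(O)c1cncc(CN2CCC[C@H](OCc3cc(Cl)cc(Cl)c3)[C@@H]2c2ccccc2)c1` has not yet been measured. It differs from compound 2 in one place: 5-carboxypyridin-3-yl in place of 1,3-oxazol-2-yl on a saturated chain carbon bound to an amine nitrogen in a ring. Compound 1 also carries a carboxylic acid on its ring attached to the saturated chain carbon and gives 22000 nM. Compound 2, without any acid, reaches only a limit in this assay. On that basis compound 3 is expected to come in at a smaller amount than compound 2 in this assay, a step of an at least 4.0-fold lower number from compound 2 to compound 3 (0.60 log units; beyond the scatter) whose size is uncertain since compound 2 is a limit. The estimate for compound 3 is 50000 nM, within 15000 nM to 200000 nM.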

Compound 3, half-maximal effective concentration: 117000 nM
For compound 3 the middle estimate is 2.3-fold (0.37 log units) below the measured one; the measured number falls inside the stated range.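

In this assay, putting 5-carboxypyridin-3-yl in place of 1,3-oxazol-2-yl on a saturated chain carbon bound to an amine nitrogen in a ring gives an at least 1.7-fold lower number from compound 2 to compound 3 (0.23 log units; that floor lies within the scatter). This place therefore tolerates the larger group, and compound 3, at 117000 nM, gives a real number where the earlier oxazole compound gave none, though the data show no clear gain beyond the scatter. Compound 2 stands at a limit and not at a number, so the step gives only a floor and its true size remains unknown: the limit of > 200000 nM in this assay, at which 1 of the 3 values shown sits.

On these data alone, the change swaps the ring and adds the carboxylic acid at once, so it remains open whether either one alone accounts for the reading; a plain pyridin-3-yl or a 3-carboxyphenyl group at this place would separate the two. Also open, as far as these compounds go, is whether the acid itself is needed or whether a primary amide or a tetrazole would read the same, and compound 1 differs from compound 3 in more than one place, so it cannot settle these questions.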